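A Methoxyphenyl Analogue of Compound 1 Awaits Measurement

The compounds below may be only part of what the source reports. "The series", "measured", "known", "first", "only" and "open" are said of these compounds alone.

Compound 1 `O=C1c2ccccc2S(=O)(=O)N1CCCCN1CCN(c2cccc(C(F)(F)F)c2)CC1` was examined in an assay on isolated protein for binding affinity to D(4) dopamine receptor (Homo sapiens); on this read-out higher numbers stand for weaker inhibition and lower numbers for stronger inhibition. In this assay compound 1 gives > 5000 nM, which is a limit of the assay rather than a number. That places it at the limit of > 5000 nM in this assay, at which 1 of the 3 values shown sits. Two further members, compound 2 `O=C1c2ccccc2S(=O)(=O)N1CCCN1CCN(c2cccc(C(F)(F)F)c2)CC1` and compound 3 `O=C1c2ccccc2S(=O)(=O)N1CCCCCCN1CCN(c2ncccn2)CC1`, carry no single number: compound 2 gives "not determined" (no result reported) and compound 3 gives "not determined" (no result reported) in this assay. Compound 4 `COc1ccccc1N1CCN(CCCCN2C(=O)c3ccccc3S2(=O)=O)CC1` is not yet measured. It differs from compound 1 by 2-methoxyphenyl in place of 3-(trifluoromethyl)phenyl on an amine nitrogen in a ring. Among the measured compounds shown here, no measured step between two compounds exists, so the size of this step in this assay cannot be read from the data. A step from compound 1 toward stronger binding, beyond the usual scatter, is expected an at least 10-fold lower number from compound 1 to compound 4 (1.00 log units; beyond the scatter). For compound 4 a value of 500 nM is estimated, with a range from 50 nM to 5000 nM.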

Compound 4, inhibition constant: 79 nM
Compound 4: middle estimate off by 6.3-fold (0.80 log units), on the high side; low and high end bracket the measured number.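

In this assay, among the compounds shown here, 2-methoxyphenyl in place of 3-(trifluoromethyl)phenyl on an amine nitrogen in a ring gives an at least 63-fold lower number from compound 1 to compound 4 (1.80 log units; beyond the scatter), a large step and the first evidence that this position affects binding to this receptor. The true size of the step remains open-ended, as compound 1 gives only a limit of the assay: the limit of > 5000 nM in this assay, at which 1 of the 4 values shown sits.

The compounds shown leave open how a plain phenyl group would read at this position. They also leave open how a longer chain would read alongside 2-methoxyphenyl, and steps to compound 2 and compound 3 cannot be read.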